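Halogen swaps on the amide aryl of a quinazoline-thioether series

This account rests on a few compounds, and the source may have more. Where it says the series, first, only, none or still open, it means among the compounds named here.

Compound 1 `O=C(CSc1nc(Nc2ccccc2)c2ccccc2n1)Nc1ccccc1F` is the reference. In a functional assay on MGC-803 cells (Homo sapiens) for inhibition, read by MTT assay, with a stated time of 72 h (on this read-out higher numbers stand for weaker inhibition and lower numbers for stronger inhibition), compound 1 gives 10700 nM, the lowest of the two finite numbers here, with compound 3 nearest. Compound 3 `O=C(CSc1nc(Nc2ccccc2)c2ccccc2n1)Nc1ccc(Cl)cc1Cl` gives 12300 nM in this assay. Compound 2 `CCc1ccc(NC(=O)CSc2nc(Nc3ccccc3)c3ccccc3n2)cc1` gives > 50000 nM, which is a limit of this assay rather than a number. That value sits at the limit of > 50000 nM in this assay, at which 1 of the 3 values shown sits. The step of a 1.1-fold higher number from compound 1 to compound 3 (0.06 log units; within the scatter) stays within the scatter, whereas an at least 4.6-fold higher number from compound 1 to compound 2 (0.66 log units; beyond the scatter) is beyond it. Compound 4 `O=C(CSc1nc(Nc2ccccc2)c2ccccc2n1)Nc1ccc(F)c(Cl)c1` carries 3-chloro-4-fluorophenyl in place of 2-fluorophenyl on an amide-type nitrogen. Two halogen-bearing aryl amides, compounds 1 and 3, sit close together. The expected step is therefore a 1.4-fold higher number from compound 1 to compound 4 (0.15 log units; within the scatter). Compound 4 is therefore estimated at 15000 nM, between 6000 nM and 50000 nM.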

Compound 4, half-maximal inhibitory concentration: 20900 nM
Estimate against measurement, compound 4: 1.4-fold (0.14 log units) below; measured number inside the range.
By their numbers in this assay, from the lowest: compounds 1, 3 and 4 (each within the scatter of the next). At a limit, above all of these: compound 2.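

With 3-chloro-4-fluorophenyl on the amide nitrogen, a third halogen pattern stays within the scatter of the other two: a 2.0-fold higher number from compound 1 to compound 4 (0.29 log units; within the scatter) and a 1.7-fold higher number from compound 3 to compound 4 (0.23 log units; within the scatter). Compound 4 also separates from the 4-ethylphenyl amide, with an at least 2.3-fold lower number from compound 2 to compound 4 (0.37 log units; beyond the scatter). The value of compound 2, > 50000 nM, is a limit and not a number.

Going by these compounds, what a methoxy group or an amine on this aryl ring would do remains open. So does whether a 2-ethylphenyl amide would follow compound 2 or the halogen-bearing compounds.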